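From Chloro to Ethynyl: Estimating Compound 4

This account rests on a few compounds, and the source may have more. Where it says the series, first, only, none or still open, it means among the compounds named here.

In an ADME assay on the whole organism (Rattus norvegicus) for pharmacokinetics, read by HPLC, at a dose of 3 mg/kg by the oral route (a lower number here means less compound in the circulation, a higher number more compound in the circulation at the dose given), compound 1 (`N#Cc1cc(C(=O)N2CCc3ccccc32)cc(C2CC2)c1O`) gives 4470 nM and compound 2 (`N#Cc1cc(C(=O)N2CSc3ccccc32)cc(C(F)(F)F)c1O`) gives 8990 nM in the same test. Compound 3 (`N#Cc1cc(C(=O)N2CS(=O)(=O)c3ccccc32)cc(Cl)c1O`) gives 3870 nM and sits within the scatter of compound 1, while compound 2 stands beyond the scatter above compound 3. Compound 4 (`C#Cc1cc(C(=O)N2CS(=O)(=O)c3ccccc32)cc(C#N)c1O`) has ethynyl in place of chloro on an aromatic carbon, with the rest of compound 3 unchanged. Among the measured compounds shown here, no measured pair differs in one place only, so nothing here shows how such a swap behaves. With compound 3 at 3870 nM as the anchor, no step beyond the scatter is expected in this assay and no firm direction can be named. The step expected is a 1.1-fold lower number from compound 3 to compound 4 (0.04 log units; within the scatter) in size. Compound 4 is estimated at 3500 nM (range 1500 nM to 8000 nM).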

Compound 4, maximal plasma concentration: 4670 nM
Beside the measured number, compound 4's estimate is 1.3-fold (0.13 log units) below it; the range from low to high includes it.
By their numbers in this assay, from the lowest: compounds 3, 1, 4 and 2 (each within the scatter of the next, the first and the last beyond it).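

Among the compounds shown here, this is the first pair here that differs in one place only. In this assay, ethynyl in place of chloro, ortho to a hydroxy group, gives a 1.2-fold higher number from compound 3 to compound 4 (0.08 log units; within the scatter) for the amount in the circulation. At this position, then, one chlorine can give way to two carbons with no step beyond the scatter. Nothing available explains this result. From the compounds shown here alone, whether an amine, a carboxylic acid or a longer chain at this position would behave the same stays open, as does the same swap on a different core.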